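Thiophene for chlorophenyl on the triazole core

The compounds below may be only part of what the source reports. "The series", "measured", "known", "first", "only" and "open" are said of these compounds alone.

Going by the values given here, compound 1 `O=C(NO)c1ccc(NCc2nc(-c3cccc(Cl)c3)nn2-c2ccccc2)cc1` is one of two compounds measured so far in an assay on Sf9 cells for inhibition of protein deacetylase HDAC6 (Homo sapiens), read by fluorescence, with a stated time of 40 min (a lower number here means a stronger inhibitor, a higher number a weaker inhibitor), where compound 1 gives 115 nM. Compound 2 `COc1ccc(-n2nc(-c3ccc(O)cc3)nc2CNc2ccc(C(=O)NO)cc2)cc1` gives 102 nM in this assay; the two numbers sit within the scatter of each other, so no order can be drawn from them. Compound 3 `Cc1ccc(-c2nc(CNc3ccc(C(=O)NO)cc3)n(-c3ccccc3)n2)s1` has not yet been measured. It differs from compound 1 in one place: 5-methylthiophen-2-yl in place of 3-chlorophenyl on an aromatic carbon, with the rest of the shared core unchanged. Among the compounds with values here, no measured pair shows what such a change does here, and the two values to hand differ only within the scatter. A small step is therefore expected, a 1.1-fold higher number from compound 1 to compound 3 (0.05 log units; within the scatter), none beyond the scatter in either direction. For compound 3 the estimate is 130 nM, with a range from 50 nM to 350 nM.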

Compound 3, half-maximal inhibitory concentration: 30.6 nM
Compound 3: the middle estimate sits 4.2-fold (0.63 log units) above what was measured; measured number below the stated range.
By their numbers in this assay, from the lowest: compound 3; then compounds 2 and 1 (each within the scatter of the next).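

This position, on the aromatic carbon between two ring nitrogen atoms, is sensitive to the group it carries: in this assay, 5-methylthiophen-2-yl in place of 3-chlorophenyl gives a 3.8-fold lower number from compound 1 to compound 3 (0.57 log units; beyond the scatter). The earlier compounds shown here could not show this, as they differ in more than one place and their values lie within the scatter of each other. Nothing at hand accounts for the size or direction of this step.

The change replaces the ring, removes the chlorine and adds the methyl all at once, so the compounds shown do not tell which of these carries the step; unsubstituted thiophen-2-yl and 3-methylphenyl at this position would separate them. Also open, on these data alone, is how the position responds to a group of another kind, such as an amine or a carboxylic acid on the ring.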